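Swapping the thiophene ketone for a benzoyl group

The compounds below may be only part of what the source reports. "The series", "measured", "known", "first", "only" and "open" are said of these compounds alone.

The series rests on a shared core carrying a thiophen-2-yl group on a carbonyl carbon. Compound 1 `O=C(C1=C(O)C(=O)N(c2nccs2)C1c1cccs1)c1cccs1` gives 9800 nM in an assay on cells for inhibition of Suppressor of tumorigenicity 14 protein (Homo sapiens), read by ELISA; on this read-out lower numbers stand for stronger inhibition and higher numbers for weaker inhibition. Within the data shown here, compound 2 `Cc1nc(N2C(=O)C(O)=C(C(=O)c3cccs3)C2c2cccs2)sc1C`, which carries a 4,5-dimethyl-1,3-thiazol-2-yl group in place of the 1,3-thiazol-2-yl group on the amide-type nitrogen in the ring, gives 2600 nM in this assay, the lowest of the two numbers measured so far, separated from compound 1 by a 3.8-fold lower number from compound 1 to compound 2 (0.58 log units; beyond the scatter).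

Compound 3 `Cc1nc(N2C(=O)C(O)=C(C(=O)c3ccccc3)C2c2cccs2)sc1C` has not yet been measured. It differs from compound 2 in one place: phenyl in place of thiophen-2-yl on a carbonyl carbon. Among the measured compounds shown here, no measured step touches this position; the only step in hand, from compound 1 to compound 2, alters the substituent on the ring nitrogen and leaves the ketone side untouched, so it offers no direct guide. The change is a swap between two aromatic rings of similar size at the same place. Compound 3 is therefore expected to stay close to compound 2, the step of a 1.2-fold higher number from compound 2 to compound 3 (0.06 log units; within the scatter) most likely falling within the scatter in either direction. The estimate for compound 3 in this assay is 3000 nM, with a range from 1000 nM to 9000 nM.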

Compound 3, half-maximal inhibitory concentration: 21800 nM
For compound 3 the middle estimate is 7.3-fold (0.86 log units) below the measured one; the whole stated range lies below it.
By their numbers in this assay, from the lowest: compound 2; then compound 1; then compound 3.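

The ketone side of the shared core, which the earlier step left untouched, proves sensitive in this assay: phenyl in place of thiophen-2-yl on the carbonyl carbon gives an 8.4-fold higher number from compound 2 to compound 3 (0.92 log units; beyond the scatter). The two aromatic rings are therefore not interchangeable at this place, even though the change only replaces a five-membered aromatic ring with 1 hetero atom by a six-membered aromatic ring of carbon only. The series now has two single-place steps that change the number in opposite directions, and the step on the ketone side, the larger of the two, moves it upwards, whereas the step on the amide-type nitrogen in the ring gives a 3.8-fold lower number from compound 1 to compound 2 (0.58 log units; beyond the scatter).

No available evidence bears on what lies behind the step on the ketone side. The compounds shown leave open whether ring size or the ring sulfur is what counts here, a question that a furan-2-yl or a pyridin-2-yl group on the same carbonyl carbon could help to separate, and whether the step would be the same size with the 1,3-thiazol-2-yl group on the ring nitrogen.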